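This account rests on a few compounds, and the source may have more. Where it says the series, first, only, none or still open, it means among the compounds named here.

Measured so far in an in vitro functional assay on 1321-N1 cells for antagonist activity at transient receptor potential cation channel subfamily V member 1 (Homo sapiens), read by FLIPR and calcium flux; a lower number here means a stronger inhibitor, a higher number a weaker inhibitor:
compound 1 `CC(C)(C)c1ccc(NC(=O)C2=CCN(c3ncccc3C(F)(F)F)CC2)cc1`, 6 nM
compound 2 `O=C(Nc1ccc(Cl)cc1)C1=CCN(c2ncccc2C(F)(F)F)CC1`, 19 nM
compound 3 `O=C(Nc1ccc(C(F)(F)F)cc1)C1=CCN(c2ncccc2C(F)(F)F)CC1`, 8 nM

Compound 1 gives the lowest number of the three; compound 3 sits within the scatter of it, while the furthest step is a 3.2-fold higher number from compound 1 to compound 2 (0.50 log units; beyond the scatter). Compound 4 `CC(C)(C)c1ccc(NC(=O)C2=CCN(c3ncccc3C#N)CC2)cc1` differs from compound 1 only in cyano in place of trifluoromethyl on an aromatic carbon. Among the measured compounds shown here, none of the measured steps bears on this change: a 3.2-fold higher number from compound 1 to compound 2 (0.50 log units; beyond the scatter), a 1.3-fold higher number from compound 1 to compound 3 (0.12 log units; within the scatter) and a 2.4-fold lower number from compound 2 to compound 3 (0.38 log units; beyond the scatter) all alter a group elsewhere in the shared core, and the position altered in compound 4 is kept constant throughout. There is thus no basis for a directed expectation in this assay; a step no larger than the modest ones seen so far is assumed, with wide uncertainty. Compound 4 is estimated at 15 nM, range 4 nM to 60 nM. That estimate corresponds to an expected 2.5-fold higher number from compound 1 to compound 4 (0.40 log units; beyond the scatter).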

Compound 4, half-maximal inhibitory concentration: 78 nM
Compound 4: the middle estimate sits 5.2-fold (0.72 log units) below what was measured; measured number outside the range, above it.
By their numbers in this assay, from the lowest: compounds 1 and 3 (each within the scatter of the next); then compound 2; then compound 4.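

In this assay, the aromatic carbon two atoms from the ring nitrogen proves sensitive to the group it carries: cyano in place of trifluoromethyl gives a 13-fold higher number from compound 1 to compound 4 (1.11 log units; beyond the scatter) and is a larger step than any seen on replacing tert-butyl. On the core of compound 1, the two groups are therefore not interchangeable. No measurement shown accounts for this step.

Going by these compounds, whether the step carries over to the chloro and trifluoromethyl partners in compound 2 and compound 3 remains open. So does the outcome with a methyl or methoxy group at this position.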